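The source may hold more compounds than are shown below. What is called first, only, known or untested is meant among the compounds shown, and "the series" means these compounds.

Three members of this series have been examined in a functional assay on DU-145 cells (Homo sapiens) for cytotoxicity, read by sulforhodamine B assay, with a stated time of 48 h (on this read-out higher numbers stand for weaker inhibition of growth and lower numbers for stronger inhibition of growth), and all three share one core, differing only in the amine borne on it. Compound 1 `N#Cc1ccc(Nc2nc(Oc3ccnc4ccccc34)nc(N3CCN(C(c4ccccc4)c4ccc(Cl)cc4)CC3)n2)cc1C(F)(F)F` is the odd one out: in this assay compound 1 reaches only a limit of > 100000 nM, a number that is a boundary of the assay and not a measurement. Compound 2 `CC1CC(C)CN(c2nc(Nc3ccc(C#N)c(C(F)(F)F)c3)nc(Oc3ccnc4ccccc34)n2)C1` gives in this assay a value of 68000 nM, and compound 3 `N#Cc1ccc(Nc2nc(Oc3ccnc4ccccc34)nc(N3CCN(c4cccc(C(F)(F)F)c4)CC3)n2)cc1C(F)(F)F` gives in this assay a value of 74100 nM. The two numbers for compound 2 and compound 3 lie within the usual scatter of one another, so neither can be set above the other; both sit well clear of the limit noted for compound 1 (the limit of > 100000 nM in this assay, at which 1 of the 3 values shown sits).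

Compound 4 `CCN1CCN(c2nc(Nc3ccc(C#N)c(C(F)(F)F)c3)nc(Oc3ccnc4ccccc34)n2)CC1` has not yet been measured. It differs from compound 2 in one place: 4-ethylpiperazin-1-yl in place of 3,5-dimethylpiperidin-1-yl on an aromatic carbon. For the measured compounds named here, no pair of measured compounds shows this exact exchange, so the size of the step cannot be read from the data. Compound 4 is expected to stay in the same weak region, with a step from compound 2 of a 1.2-fold higher number from compound 2 to compound 4 (0.07 log units; within the scatter), that is, no change beyond the scatter. For compound 4 the estimate in this assay is 80000 nM, with a range from 30000 nM to 200000 nM.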

Compound 4, concentration for total growth inhibition: > 100000 nM
Compound 4 was reported as a limit (the forecaster's own chance of this, stated with the estimate: 35%); middle value at least 1.2-fold (0.09 log units) away from the limit.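

Compound 4 is reported in this assay only as a limit, so the exchange at this position, on an aromatic carbon between two ring nitrogen atoms, can be given only as a floor: an at least 1.4-fold higher number from compound 2 to compound 4 (0.16 log units; that floor lies within the scatter). The change on the amine nitrogen in a ring, with ethyl taking the place of 3-(trifluoromethyl)phenyl, likewise gives only a floor: an at least 1.3-fold higher number from compound 3 to compound 4 (0.13 log units; that floor lies within the scatter). Neither floor establishes a real loss, but the result does show that carrying 4-ethylpiperazin-1-yl at this position leaves the compound at the assay's limit, so the group that enters does not bring a number inside the measured range, and the series now has a second compound there: the limit of > 100000 nM in this assay, at which 2 of the 4 values shown sit.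

On these data alone, how far compound 4 actually lies from compound 2 and compound 3 remains unknown, and so the true size of both steps cannot be read. The compounds shown also leave open whether a morpholin-4-yl group or an unsubstituted piperazin-1-yl group at this position would give a number or another limit.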